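Swapping an Aromatic Side Group: Expected Solubility of Compound 4

The source may hold more compounds than are shown below. What is called first, only, known or untested is meant among the compounds shown, and "the series" means these compounds.

Compound 1 `COc1cccc(CNCCCNc2ccnc3cc(Oc4ccc(F)cc4)ccc23)c1O`: 14500 nM
Compound 2 `COc1cccc(Oc2ccc3c(NCCCNCc4cccc(OC)c4O)ccnc3c2)c1`: 14500 nM
Compound 3 `COc1cccc(CNCCCNc2ccnc3cc(Cc4cccc(C(F)(F)F)c4)ccc23)c1O`: 4200 nM

In a physicochemical assay for solubility, with a stated time of 18 h, at pH 7.4 (a lower number here means a less soluble compound, a higher number a more soluble compound), compound 3 stands lowest of the three numbers: a 3.5-fold lower number from compound 1 to compound 3 (0.54 log units; beyond the scatter) and a 3.5-fold lower number from compound 2 to compound 3 (0.54 log units; beyond the scatter), whereas no change at the digits printed from compound 1 to compound 2 (within the scatter). Compound 4 `COc1ccc(-c2ccc3c(NCCCNCc4cccc(OC)c4O)ccnc3c2)cc1` differs from compound 3 by 4-methoxyphenyl in place of 3-(trifluoromethyl)benzyl on an aromatic carbon. Among the measured compounds shown here, no measured step makes exactly this kind of exchange. The two steps that bear on it each put a 3-(trifluoromethyl)benzyl group in place of a phenoxy group and were modest in size. Reversing part of that direction, compound 4 is expected to show a 2.1-fold higher number from compound 3 to compound 4 (0.33 log units; beyond the scatter). Compound 4 is therefore estimated at 9000 nM, with a range from 3500 nM to 25000 nM.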

Compound 4, solubility: 32000 nM
Beside the measured number, compound 4's estimate is 3.6-fold (0.55 log units) below it; the measured number lies above the stated range.
By their numbers in this assay, from the lowest: compound 3; then compounds 1 and 2 (each within the scatter of the next); then compound 4.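

Compound 4 stands highest of the four in this assay with a 7.6-fold higher number from compound 3 to compound 4 (0.88 log units; beyond the scatter) and a 2.2-fold higher number from compound 2 to compound 4 (0.34 log units; beyond the scatter) and a 2.2-fold higher number from compound 1 to compound 4 (0.34 log units; beyond the scatter) as its steps. The earlier compounds shown here all hold their aromatic ring on the shared core through an oxygen or a carbon, so compound 4 adds something new: with 4-methoxyphenyl, a ring joined with no such link keeps the number high. Nothing measured here gives a reason for this rise. From the compounds shown here alone, whether an amine or a carboxylic acid on that ring would raise the number further stays open.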